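From 4-methylpiperazin-1-yl to methyl(phenyl)amino on a shared core

This account rests on a few compounds, and the source may have more. Where it says the series, first, only, none or still open, it means among the compounds named here.

In a functional assay on L02 cells (Homo sapiens) for inhibition, read by Griess assay, with stated times of 1 h and 24 h (a lower number here means a stronger inhibitor, a higher number a weaker inhibitor), the measured compounds share one core and differ in the group on one aromatic carbon. Compound 1 (`CNc1nc(/C=C/c2ccccc2)nc2ccsc12`) reads > 1000000 nM, which is a limit of the assay and not a number. Compound 2 (`CC(C)CNc1nc(/C=C/c2ccccc2)nc2ccsc12`) reads > 1000000 nM, which is also a limit. For the measured compounds named here, compound 3 (`CN1CCN(c2nc(/C=C/c3ccccc3)nc3ccsc23)CC1`) gives 198000 nM, the only true number so far.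

Compound 4 (`CN(c1ccccc1)c1nc(/C=C/c2ccccc2)nc2ccsc12`) carries methyl(phenyl)amino in place of 4-methylpiperazin-1-yl on an aromatic carbon.

Going by the values given here, two measured steps bear on this change, as both end at 4-methylpiperazin-1-yl: an at least 5.0-fold lower number from compound 1 to compound 3 (0.70 log units; beyond the scatter), and an at least 5.0-fold lower number from compound 2 to compound 3 (0.70 log units; beyond the scatter). Each is a minimum size, not an exact one. The step that the two limits leave unreadable from compound 1 to compound 2 adds nothing. Compound 4 gives up the group that compound 3 carries, and the new group matches neither methylamino nor isobutylamino, so only part of that gain is expected to be lost. The estimated change is a 2.3-fold higher number from compound 3 to compound 4 (0.36 log units; beyond the scatter), toward a weaker inhibitor. A reading at the limit remains possible. For compound 4, the expected value is 450000 nM, with an estimated range of 120000 nM to 1000000 nM.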

Compound 4, half-maximal inhibitory concentration: > 1000000 nM
Compound 4 was reported as a limit; the forecaster's own chance of this, stated with the estimate: 35%; at least 2.2-fold (0.34 log units) between middle value and limit.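

In this assay, putting methyl(phenyl)amino in place of 4-methylpiperazin-1-yl gives an at least 5.0-fold higher number from compound 3 to compound 4 (0.70 log units; beyond the scatter), so the gain seen with 4-methylpiperazin-1-yl does not carry over to this other group on the same aromatic carbon. Compound 4 reads > 1000000 nM, which is a limit of the assay and not a number, and its steps from compound 1 and compound 2 join two limits and cannot be read. Like compound 3, compound 4 has no hydrogen on the nitrogen attached to the shared core, so losing that hydrogen is not enough on its own, and compound 3 now stands alone with a true number against one shared ceiling: the limit of > 1000000 nM in this assay, at which 3 of the 4 values shown sit.

Still open, on these data alone, is which feature of 4-methylpiperazin-1-yl matters: the second ring nitrogen, the non-aromatic ring itself or the methyl group on it. For the compounds shown here, a morpholine, a piperidine or a piperazine without the methyl group on this carbon would help separate these, and with only one true number in hand, the size of any such effect is also unknown.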